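This account rests on a few compounds, and the source may have more. Where it says the series, first, only, none or still open, it means among the compounds named here.

The series shares one core. Compound 1 `COc1cc(-c2nnc3n2NC(c2cccs2)C(C(=O)c2ccc(C)cc2)S3)cc(OC)c1OC` carries a 4-methylphenyl on its carbonyl carbon, compound 2 `COc1cc(-c2nnc3n2NC(c2ccco2)C(C(=O)c2ccc(F)c(F)c2)S3)cc(OC)c1OC` a 3,4-difluorophenyl, and compound 3 `COc1cc(-c2nnc3n2NC(c2ccco2)C(C(=O)c2cccc(Br)c2)S3)cc(OC)c1OC` a 3-bromophenyl. In a functional assay on A549 cells (Homo sapiens) for cytotoxicity, read by MTT assay, with a stated time of 48 h (on this read-out lower numbers stand for stronger inhibition and higher numbers for weaker inhibition), compound 1 gives 12700 nM, compound 2 gives 93700 nM, and compound 3 gives 36900 nM. Among these three numbers compound 2 stands highest; its nearest neighbour is compound 3, and compound 1 lies furthest from it.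

The unmeasured compound 4 `COc1cc(-c2nnc3n2NC(c2ccco2)C(C(=O)c2cccs2)S3)cc(OC)c1OC` differs from compound 2 at a single place: thiophen-2-yl in place of 3,4-difluorophenyl on a carbonyl carbon. Among the measured compounds shown here, the only measured step at that same carbonyl carbon is a 2.5-fold lower number from compound 2 to compound 3 (0.40 log units; beyond the scatter), a modest change beyond the scatter when one six-membered aromatic ring replaces another. For the measured compounds named here, no measured step exchanges a six-membered aromatic ring for thiophen-2-yl on a carbonyl carbon, so the direction for compound 4 rests on the fact that compound 2 gives the highest number and that the one change made at this position moved the number down. A modest downward step is therefore expected, a 2.3-fold lower number from compound 2 to compound 4 (0.37 log units; beyond the scatter), with wide uncertainty. Compound 4 is estimated to give 40000 nM in this assay, expected to fall between 15000 nM and 100000 nM.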

Compound 4, half-maximal inhibitory concentration: 78700 nM
Compound 4: middle estimate off by 2.0-fold (0.29 log units), on the low side; the range from low to high includes it.
By their numbers in this assay, from the lowest: compound 1; then compound 3; then compounds 4 and 2 (each within the scatter of the next).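

Exchanging the six-membered 3,4-difluorophenyl for the five-membered thiophen-2-yl on the carbonyl carbon gives a 1.2-fold lower number from compound 2 to compound 4 (0.08 log units; within the scatter), so in this assay this change of ring and of heavy-atom count does not separate compound 2 from compound 4. Among the compounds shown here, the same thiophen-2-yl set against 3-bromophenyl gives a 2.1-fold higher number from compound 3 to compound 4 (0.33 log units; beyond the scatter), which shows that, with the step from compound 2 to compound 3 now joined by a second one, 3-bromophenyl is the only one of these three groups on the carbonyl carbon that stands apart, and only modestly. Nothing measured here accounts for this difference among the groups.

Compound 1 differs from each of the others in two places, so these compounds do not show whether its number belongs to its 4-methylphenyl or to something else in its structure. They also leave open how the number would respond to an unsubstituted phenyl, a saturated cyclohexyl, an amine or a carboxylic acid on this carbonyl carbon, and whether any such group could reach beyond the narrow range seen so far.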